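The source may hold more compounds than are shown below. What is called first, only, known or untested is meant among the compounds shown, and "the series" means these compounds.

Measured compounds:
- compound 1, `Cc1cc(C)cc(NC(=O)COc2ccnc3ccccc23)c1`: 5.03
- compound 2, `COc1ccc2nc(C)cc(OCC(=O)Nc3cc(C)cc(C)c3)c2c1`: 5.64

In a physicochemical assay for lipophilicity, at pH 7.4 (a higher number here means a more lipophilic compound, a lower number a more polar compound), compound 2 gives 5.64, the higher of the two numbers recorded so far. In this assay compound 1 gives 5.03, which lies lower than compound 2 by a gap that goes beyond the scatter; the two compounds differ in more than one place, so their values can only be set side by side, not traced to a single change.

Compound 3, `COc1ccc2nccc(OCC(=O)Nc3cc(C)cc(C)c3)c2c1`, has not yet been measured in this assay. It differs from compound 2 in one place: hydrogen in place of methyl on an aromatic carbon. Among the measured compounds shown here, no measured pair in this set isolates this change, so the size of the step has to be judged from the change alone. Taking away a methyl and leaving a hydrogen in its place is expected to lower the distribution coefficient by a modest amount, probably somewhat beyond the scatter of the assay but not by a large margin.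

On that basis compound 3 is expected to give about 5.2 in this assay, within a range of 4.8 to 5.6, which is a step of a number 0.44 log units lower from compound 2 to compound 3 (beyond the scatter) downward as estimated.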

Compound 3, distribution coefficient: 5.3
For compound 3 the middle estimate is 0.10 log units below the measured one; the range from low to high includes it.
By their numbers in this assay, from the lowest: compounds 1 and 3 (each within the scatter of the next); then compound 2.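

Hydrogen in place of methyl on an aromatic carbon next to the ring nitrogen gives, in this assay, a number 0.34 log units lower from compound 2 to compound 3 (beyond the scatter); this is the first reading of a single change at this position, where compounds 1 and 2 could only be set side by side. The second change now isolated, methoxy in place of hydrogen on an aromatic carbon, gives a number 0.27 log units higher from compound 1 to compound 3 (within the scatter), so of the two single changes only the loss of the methyl carries a step beyond the scatter. Nothing available here accounts for the size of either step.

The compounds shown leave open how a longer chain such as ethyl, a chlorine atom or an amine on this same aromatic carbon would stand in this assay, as only methyl and hydrogen appear there. They also leave open whether the step from methyl to hydrogen keeps its size on a core without the methoxy group, a reading that would need a partner for compound 1 carrying the methyl alone.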